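Variation of the Aminopyrimidine Side Chain: Toward Compound 4

The compounds below may be only part of what the source reports. "The series", "measured", "known", "first", "only" and "open" are said of these compounds alone.

Measured so far in an assay on isolated protein for inhibition of Polyunsaturated fatty acid 5-lipoxygenase (Homo sapiens); on this read-out lower numbers stand for stronger inhibition and higher numbers for weaker inhibition:
- compound 1 `O=C(O)C(Sc1nc(Cl)cc(Nc2cccc(Cl)c2)n1)c1cccc2ccccc12`: 700 nM
- compound 2 `O=C(O)C(Sc1nc(Cl)cc(Nc2ccc(F)cc2)n1)c1cccc2ccccc12`: 3100 nM
- compound 3 `CC(C)CCNc1cc(Cl)nc(SC(C(=O)O)c2cccc3ccccc23)n1`: 2500 nM

Compound 2 gives the highest number of the three; its nearest neighbour is compound 3 (a 1.2-fold lower number from compound 2 to compound 3 (0.09 log units; within the scatter)), and compound 1 lies furthest away (a 4.4-fold higher number from compound 1 to compound 2 (0.65 log units; beyond the scatter)). Compound 4 `O=C(O)C(Sc1nc(Cl)cc(Nc2ccc(C3CCCCC3)cc2)n1)c1cccc2ccccc12` is not yet measured. It differs from compound 2 only at the aryl on the nitrogen: cyclohexyl in place of fluoro on an aromatic carbon. Within the data shown here, no measured step changes a substituent on that phenyl; the steps that bear on it are those exchanging the whole group, a 4.4-fold higher number from compound 1 to compound 2 (0.65 log units; beyond the scatter) and a 3.6-fold higher number from compound 1 to compound 3 (0.55 log units; beyond the scatter), both modest and both beyond the scatter. The change to compound 4 is therefore expected to move this assay by a modest amount at most, more likely toward a lower number, as a 2.1-fold lower number from compound 2 to compound 4 (0.32 log units; beyond the scatter). Compound 4 is estimated at 1500 nM, with a range from 400 nM to 6000 nM.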

Compound 4, half-maximal inhibitory concentration: 400 nM
Beside the measured number, compound 4's estimate is 3.8-fold (0.57 log units) above it; measured number inside the range.
By their numbers in this assay, from the lowest: compounds 4 and 1 (each within the scatter of the next); then compounds 3 and 2 (each within the scatter of the next).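

In this assay, the phenyl on the nitrogen accepts a much larger substituent on this aromatic carbon, para to a large group, with cyclohexyl in place of fluoro giving a 7.8-fold lower number from compound 2 to compound 4 (0.89 log units; beyond the scatter) in this series. Among these compounds, this is the first measured step that changes a substituent on that phenyl rather than exchanging the whole group, and it shows that this single position alone can shift the read-out beyond the scatter. Nothing available explains the step.

Open, on these data alone, is whether the ring itself matters or only the added carbon atoms, which a hexyl chain or a phenyl at the same place would test. A morpholine there would show whether a ring containing nitrogen and oxygen is accepted as well.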